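Shortening the hydroxyalkyl arm on a Toll-like receptor 8 agonist

The source may report more compounds than this note shows. Statements on the series, on what has been measured and on what is new or still open speak of the compounds shown alone.

Of the compounds shown here, two built on one shared core have been measured so far. Compound 1 `CCC[C@@H](CO)Nc1nc(N)nc(C)c1Cc1ccc(CNCCO)cc1OC` gives 5370 nM in an assay on HEK293 cells for agonist activity at Toll-like receptor 8 (Homo sapiens); on this read-out lower numbers stand for an effect already at smaller amounts and higher numbers for an effect only at larger amounts of compound. Compound 2 `CCC[C@@H](CCO)Nc1nc(N)nc(C)c1Cc1ccc(CNC)cc1OC` gives 6460 nM in this assay, the higher of the two numbers, but its nearest neighbour is compound 1 and the two values lie within the scatter of each other, so nothing separates them. Compound 1 and compound 2 also differ in two places at once, so neither change can be read off on its own.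

Compound 3 `CCC[C@@H](CO)Nc1nc(N)nc(C)c1Cc1ccc(CNC)cc1OC` is not yet measured. It keeps the rest of compound 2 unchanged and alters only the arm on the saturated chain: hydroxy in place of hydroxymethyl on a saturated chain carbon, two bonds along the chain from a nitrogen on an aromatic ring. Among the measured compounds shown here, no measured pair isolates this change. For the measured compounds named here, the only guidance is that compound 1, which carries the shorter arm, and compound 2, which carries the longer one, sit so close together. The step from compound 2 to compound 3 is therefore expected to be small, a 1.3-fold lower number from compound 2 to compound 3 (0.13 log units; within the scatter), and to stay within the scatter, perhaps leaning toward a lower number. Compound 3 is estimated at 4800 nM, with a likely range from 2000 nM to 11000 nM.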

Compound 3, half-maximal effective concentration: 2140 nM
Compound 3: middle estimate off by 2.2-fold (0.35 log units), on the high side; low and high end bracket the measured number.
By their numbers in this assay, from the lowest: compound 3; then compounds 1 and 2 (each within the scatter of the next).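

Compound 3 pulls apart the two changes that were mixed together in compounds 1 and 2. On the saturated chain, going from 1-(2-hydroxyethyl)butyl to 1-(hydroxymethyl)butyl gives a 3.0-fold lower number from compound 2 to compound 3 (0.48 log units; beyond the scatter) in this assay and shows that this arm responds to the loss of a single carbon, even though the hydroxy group stays. At the second place, hydrogen in place of hydroxymethyl on a saturated chain carbon bound to an amine nitrogen gives a 2.5-fold lower number from compound 1 to compound 3 (0.40 log units; beyond the scatter) and points the same way, so the closeness of compounds 1 and 2 concealed two separate steps, each beyond the scatter and each toward a lower number.

No measurement here explains why either step runs in this direction. From the compounds shown here alone, it also remains open whether the trend continues when the hydroxymethyl on the arm gives way to a plain hydrogen or an aminomethyl group, and whether a bulkier group such as cyclopropyl on the amine nitrogen would lower the number further.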